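This account rests on a few compounds, and the source may have more. Where it says the series, first, only, none or still open, it means among the compounds named here.

Measured compounds in a functional assay on 786-0 cells (Homo sapiens) for inhibition, read by sulforhodamine B assay, with a stated time of 48 h; on this read-out lower numbers stand for stronger inhibition of growth and higher numbers for weaker inhibition of growth:

compound 1, `COc1ccc(/C=C/C2(C)C=CC(=O)O2)c(OC)c1`, 108000 nM
compound 2, `COc1ccc(/C=C/C2(C)C=CC(=O)O2)cc1OC`, 22900 nM
compound 3, `COc1cc(/C=C/C2(C)C=CC(=O)O2)cc(OC)c1OC`, 116000 nM

Compound 1 and compound 2 hold the same atoms joined differently; the difference between their cores is not broken down here. Going by the values given here, the one single-point step among the measured compounds is methoxy in place of hydrogen on an aromatic carbon, which gave a 5.1-fold higher number from compound 2 to compound 3 (0.70 log units; beyond the scatter).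

Compound 4, `COc1cc(OC)c(/C=C/C2(C)C=CC(=O)O2)c(OC)c1`, is not yet measured. It differs from compound 1 by methoxy in place of hydrogen on an aromatic carbon. Among the compounds with values here, this is the same kind of change as the one from compound 2 to compound 3, though not the same: in compound 4 the entering methoxy sits ortho to a group of 9 heavy atoms and meta to two methoxy groups, whereas in compound 3 it sits ortho to a methoxy group, meta to a group of 9 heavy atoms and meta to a methoxy group. Within the data shown here, on the strength of that single step, compound 4 is expected to show a 2.3-fold higher number from compound 1 to compound 4 (0.36 log units; beyond the scatter), set beside a 5.1-fold higher number from compound 2 to compound 3 (0.70 log units; beyond the scatter), with wide uncertainty since only one such step is known. Compound 4 is therefore estimated at 250000 nM, with a plausible range from 90000 nM to 700000 nM.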

Compound 4, concentration for total growth inhibition: 459000 nM
Beside the measured number, compound 4's estimate is 1.8-fold (0.26 log units) below it, within the range that was stated.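

In this assay, methoxy in place of hydrogen on an aromatic carbon gave a 4.3-fold higher number from compound 1 to compound 4 (0.63 log units; beyond the scatter), so the same change again went with weaker inhibition of growth on a second core. The size of the step held across the two cores: the same change on two cores in this assay, a 5.1-fold higher number (0.70 log units; beyond the scatter) from compound 2 to compound 3 and a 4.3-fold higher number (0.63 log units; beyond the scatter) from compound 1 to compound 4, 1.2-fold (0.08 log units) apart, within the scatter of two such steps. Going by these compounds alone, this rests on only two pairs in one assay, with the entering methoxy in a different place in each, so it does not show that the step would hold at other places on the ring or on other cores.

The compounds shown leave open whether an amine or a carboxylic acid on the aromatic ring would move the number in the same way as methoxy. Also open, as far as these compounds go, is what a longer chain in place of the methyl group on the shared core would do.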